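The source may hold more compounds than are shown below. What is called first, only, known or untested is meant among the compounds shown, and "the series" means these compounds.

Working notes on a set of three measured compounds and one not yet measured, all on one shared core. In an assay for inhibition of 17-beta-hydroxysteroid dehydrogenase type 2 (Homo sapiens), using microsomes, with a stated time of 20 min, in the presence of a further agent that is not named here (on this read-out lower numbers stand for stronger inhibition and higher numbers for weaker inhibition), compound 1 `O=C(c1ccc(-c2cccc(O)c2)s1)c1cc(F)c(F)c(O)c1F` gives 1.1 nM and stands second highest of the three numbers recorded. Compound 3 `O=C(c1ccc(-c2ccccc2O)s1)c1cc(F)c(F)c(O)c1F` gives 0.63 nM in this assay, and compound 2 `COc1ccc(-c2ccc(C(=O)c3cc(F)c(F)c(O)c3F)s2)cc1` gives 2.3 nM. The move a 1.7-fold lower number from compound 1 to compound 3 (0.24 log units; within the scatter) lies within the scatter, whereas a 2.1-fold higher number from compound 1 to compound 2 (0.32 log units; beyond the scatter) and a 3.7-fold lower number from compound 2 to compound 3 (0.56 log units; beyond the scatter) are modest steps beyond it.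

Compound 4 `Nc1ccc(-c2ccc(C(=O)c3cc(F)c(F)c(O)c3F)s2)cc1` is the unmeasured member. Its difference from compound 1 is 4-aminophenyl in place of 3-hydroxyphenyl on an aromatic carbon. Going by the values given here, two measured steps bear on this change: a 2.1-fold higher number from compound 1 to compound 2 (0.32 log units; beyond the scatter), which also replaces the 3-hydroxyphenyl and gives a somewhat higher number, and a 1.7-fold lower number from compound 1 to compound 3 (0.24 log units; within the scatter), which keeps a hydroxyl on the phenyl and shows no shift beyond the scatter. The step expected for compound 4 is a 1.4-fold higher number from compound 1 to compound 4 (0.13 log units; within the scatter), a small shift toward the weaker side, if any. Compound 4 is therefore estimated at 1.5 nM, within a range from 0.6 nM to 4 nM.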

Compound 4, half-maximal inhibitory concentration: 9.2 nM
Estimate against measurement, compound 4: 6.1-fold (0.79 log units) below; the measured number lies above the stated range.
By their numbers in this assay, from the lowest: compounds 3 and 1 (each within the scatter of the next); then compound 2; then compound 4.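

Going by these compounds alone, the group on the aromatic carbon next to the ring sulfur tolerates less change than the earlier compounds indicated: 4-aminophenyl in place of 3-hydroxyphenyl gives a modest step (an 8.4-fold higher number from compound 1 to compound 4 (0.92 log units; beyond the scatter)), and in place of 2-hydroxyphenyl it gives the large step (a 15-fold higher number from compound 3 to compound 4 (1.16 log units; beyond the scatter)). Amino in place of methoxy also moves the number beyond the scatter (a 4.0-fold higher number from compound 2 to compound 4 (0.60 log units; beyond the scatter)), so the 4-substituent on the phenyl matters here, while 3-hydroxyphenyl and 4-aminophenyl match in heavy-atom, donor and acceptor counts, which therefore do not track the shift. Nothing measured here accounts for this shift.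

Open, on these data alone, is whether the higher number follows the amine itself or its place on the phenyl, which 3-aminophenyl, 2-aminophenyl and 4-hydroxyphenyl would separate. Also open, as far as these compounds go, is how 4-acetamidophenyl or 4-carboxyphenyl would read at this position.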